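Nitrile to primary amide on the thioether chain

This account rests on a few compounds, and the source may have more. Where it says the series, first, only, none or still open, it means among the compounds named here.

Compound 2 `N#CCSCc1nc2cc([N+](=O)[O-])ccc2[nH]1` gives 28200 nM in a functional assay on HCT-116 cells (Homo sapiens) for cytotoxicity, read by MTT assay, with a stated time of 48 h (on this read-out lower numbers stand for stronger inhibition and higher numbers for weaker inhibition), the highest of the two numbers recorded in the series. Within the data shown here, compound 1 `O=C(CSCc1nc2cc([N+](=O)[O-])ccc2[nH]1)c1ccc(Cl)cc1` gives 2230 nM in this assay, a lower number by a margin beyond the scatter; no step between these two is worked out here. Compound 3 `NC(=O)CSCc1nc2cc([N+](=O)[O-])ccc2[nH]1` carries the change (carbamoyl in place of cyano on a saturated chain carbon bound to a sulfur), carbamoyl in place of cyano on a saturated chain carbon bound to a sulfur. Among the measured compounds shown here, no measured pair shows this swap, so only a modest step is expected, a 1.4-fold lower number from compound 2 to compound 3 (0.15 log units; within the scatter), possibly none beyond the scatter. Compound 3 is estimated at 20000 nM, within 6000 nM to 60000 nM.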

Compound 3, half-maximal inhibitory concentration: 17200 nM
Compound 3: middle estimate off by 1.2-fold (0.07 log units), on the high side, within the range that was stated.
By their numbers in this assay, from the lowest: compound 1; then compounds 3 and 2 (each within the scatter of the next).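

In this assay, carbamoyl in place of cyano on a saturated chain carbon bound to a sulfur gives a 1.6-fold lower number from compound 2 to compound 3 (0.21 log units; within the scatter) and so does not separate these two compounds. The group on the carbonyl carbon does separate them: amino in place of 4-chlorophenyl gives a 7.7-fold higher number from compound 1 to compound 3 (0.89 log units; beyond the scatter) and leaves compound 3 within the scatter of compound 2. Nothing available explains either step.

From the compounds shown here alone, whether a carboxylic acid or a longer chain at this position would move the number beyond the scatter remains open. Also open, going by these compounds, is whether a phenyl without the chlorine would keep the number close to that of compound 1.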